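A few compounds are considered here, and "the series" means these few. Any claim that something is new, unique, unknown or untested is made for them only; others in the source may bear on it.

Measured compounds in a functional assay on Caco-2 cells (Homo sapiens) for antiproliferative activity, read by MTT assay, with a stated time of 48 h; a higher number here means a weaker inhibitor, a lower number a stronger inhibitor:

- compound 1 `CCn1c(C(=O)NCCN(C)C)ccc1C(CC)(CC)c1ccc(OCCC(O)(CC)CC)c(C)c1`, giving 1140 nM
- compound 2 `C#CC(C)OC(=O)c1ccc(C(CC)(CC)c2ccc(OCCC(O)(CC)CC)c(C)c2)n1CC`, for which the assay reports only a limit, > 50000 nM
- compound 3 `C#CCCOC(=O)c1ccc(C(CC)(CC)c2ccc(OCCC(O)(CC)CC)c(C)c2)n1CC`, for which the assay reports only a limit, > 50000 nM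

Compound 1 is therefore the only one of the three with a measured number in this assay; the other two sit at the limit described by the limit of > 50000 nM in this assay, at which 2 of the 3 values shown sit. The new compound 4 `CCn1c(C(=O)Nc2ccc(OC(F)(F)F)cc2)ccc1C(CC)(CC)c1ccc(OCCC(O)(CC)CC)c(C)c1` differs from compound 1 in one place: 4-(trifluoromethoxy)phenyl in place of 2-(dimethylamino)ethyl on an amide-type nitrogen. The amide is kept, but the group on its nitrogen changes.

The two measured steps that bear on this also remove the 2-(dimethylamino)ethyl group from compound 1, though each does so by changing the whole (2-(dimethylamino)ethyl)amino into an ester. Both are large: an at least 43-fold higher number from compound 1 to compound 2 (1.64 log units; beyond the scatter) and an at least 43-fold higher number from compound 1 to compound 3 (1.64 log units; beyond the scatter). Compound 4 removes the same group while keeping an amide-type nitrogen, so a step in the same direction, weaker activity, is expected, though its size is uncertain because neither an at least 43-fold higher number from compound 1 to compound 2 (1.64 log units; beyond the scatter) nor an at least 43-fold higher number from compound 1 to compound 3 (1.64 log units; beyond the scatter) gives a number beyond the limit. For compound 4 the expected result in this assay is 15000 nM, estimated between 3000 nM and 50000 nM. The expected step from compound 1 is a 13-fold higher number from compound 1 to compound 4 (1.12 log units; beyond the scatter).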

Compound 4, half-maximal inhibitory concentration: > 50000 nM
Compound 4: only a limit was reported; the forecaster's own chance of this, stated with the estimate: 35%; at least 3.3-fold (0.52 log units) between middle value and limit.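

Replacing 2-(dimethylamino)ethyl with 4-(trifluoromethoxy)phenyl on the amide-type nitrogen gives an at least 43-fold higher number from compound 1 to compound 4 (1.64 log units; beyond the scatter) in this assay. Among these compounds, in the earlier steps, the whole (2-(dimethylamino)ethyl)amino was replaced to give an ester, so the amide link and the group on it changed together. Compound 4 keeps the amide-type nitrogen and still shows a large step, so among these compounds an amide at this place does not by itself preserve the activity of compound 1, and the steps among compounds 2, 3 and 4 cannot be read because all three carry the same limit: the limit of > 50000 nM in this assay, at which 3 of the 4 values shown sit.

Compound 4 loses the 2-(dimethylamino)ethyl group and gains an aromatic ring in a single change, so the compounds shown cannot tell whether the loss, the gain or both matter. On the same nitrogen, a pentyl chain would have neither the dimethylamino group nor a ring, while a 4-(dimethylamino)phenyl group would have both, and the compounds shown leave open how either would behave.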